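Adding a methyl group to a compound at the limit

The source may report more compounds than this note shows. Statements on the series, on what has been measured and on what is new or still open speak of the compounds shown alone.

Compound 1 `Nc1nc2cc(Cl)c(Cl)cc2n1Cc1ccccc1`: 170000 nM
Compound 2 `COc1ccc(Cn2c(N)nc3cc(Cl)c(Cl)cc32)cc1`: 45000 nM
Compound 3 `Clc1cc2nc(Cl)n(Cc3ccccc3)c2cc1Cl`: > 100000 nM

All three values come from a functional assay on KB cells (Homo sapiens) for inhibition; a higher number here means a weaker inhibitor, a lower number a stronger inhibitor. Compound 3 gives > 100000 nM, which is a limit of the assay and not a number.

The next compound, compound 4 `Cc1ccc(Cn2c(Cl)nc3cc(Cl)c(Cl)cc32)cc1`, carries methyl in place of hydrogen on an aromatic carbon, para to a large group: methyl in place of hydrogen on an aromatic carbon.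

The closest measured change is a 3.8-fold lower number from compound 1 to compound 2 (0.58 log units; beyond the scatter), where methoxy replaces hydrogen on an aromatic carbon. That step is modest, and it involves a different group on a compound with amino rather than chloro. The other measured change, a step that the limit leaves unreadable from compound 1 to compound 3, gives no size to work with.

Going by a 3.8-fold lower number from compound 1 to compound 2 (0.58 log units; beyond the scatter), a modest move towards a lower number in this assay is expected, though a change within the scatter is also possible. The expected step is an at least 1.2-fold lower number from compound 3 to compound 4 (0.09 log units; that floor lies within the scatter). Compound 4 is estimated at 80000 nM, with an expected range from 25000 nM to 200000 nM.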

Compound 4, half-maximal inhibitory concentration: > 100000 nM
Compound 4: only a limit was reported; the forecaster's own chance of this, stated with the estimate: 40%; middle value at least 1.2-fold (0.09 log units) from the limit.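

No size can be read for the step between compound 3 and compound 4, because both values are limits and not numbers: the limit of > 100000 nM in this assay, at which 2 of the 4 values shown sit.

The compounds shown leave open whether methyl in place of hydrogen on an aromatic carbon changes inhibition at all, and by how much.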